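Compound 3 to compound 4: a step near a limit

The source may hold more compounds than are shown below. What is called first, only, known or untested is meant among the compounds shown, and "the series" means these compounds.

In an ADME assay on HEK293 cells (Homo sapiens) for cytotoxicity, read by CCK-8 assay, with a stated time of 48 h (a higher number here means a weaker inhibitor, a lower number a stronger inhibitor), compound 3 (`COc1ccc(/C=C\c2cc(OC)c(OC)c(OC)c2)cc1OCc1ccc(CN[C@H](C(=O)O)[C@H](C)O)cc1`) gives > 50000 nM as a limit and not a number. Compound 1 (`COc1ccc(/C=C\c2cc(OC)c(OC)c(OC)c2)cc1OCc1ccc(CNC(C)(C)C(=O)O)cc1`) gives > 50000 nM which is also a limit. Compound 3 thus stands at the limit of > 50000 nM in this assay, at which 2 of the 3 values shown sit, and no more exact place can be given for it. Among the compounds with values here, compound 2 (`COc1ccc(/C=C\c2cc(OC)c(OC)c(OC)c2)cc1OCc1ccc(CN2CCCC[C@@H]2C(=O)O)cc1`) gives 42000 nM as the one actual number so far.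

Compound 4 (`COc1ccc(/C=C\c2cc(OC)c(OC)c(OC)c2)cc1OCc1ccc(CN2CC(C(=O)O)C2)cc1`) differs from compound 3 by one exchange on the shared core: 3-carboxyazetidin-1-yl in place of (1-carboxy-2-hydroxypropyl)amino on a saturated chain carbon bound to an aromatic carbon. Three measured steps change this same place. Of these, an at least 1.1-fold lower number from compound 1 to compound 2 (0.07 log units; that floor lies within the scatter) and an at least 1.1-fold higher number from compound 2 to compound 3 (0.07 log units; that floor lies within the scatter) show no floor beyond the scatter, and a step that the two limits leave unreadable from compound 1 to compound 3 gives no size at all. On those steps, no change beyond the scatter is expected in this assay for this exchange, and compound 4 may also report only as a limit. The estimated step is an at least 1.1-fold lower number from compound 3 to compound 4 (0.04 log units; that floor lies within the scatter) on this reasoning. Compound 4 is expected at 45000 nM with a range of 20000 nM to 70000 nM on this estimate.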

Compound 4, half-maximal inhibitory concentration: > 50000 nM
Compound 4 was reported as a limit; the forecaster's own chance of this, stated with the estimate: 55%; middle value at least 1.1-fold (0.04 log units) from the limit.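

In this assay compound 4 reports only a limit and not a number, so a four-membered ring at this place, on a saturated chain carbon bound to an aromatic carbon, stands with the open-chain groups at that same limit: the limit of > 50000 nM in this assay, at which 3 of the 4 values shown sit.

Within the data shown here, the one step that can be read is an at least 1.1-fold higher number from compound 2 to compound 4 (0.07 log units; that floor lies within the scatter), so exchanging 2-carboxypiperidin-1-yl for 3-carboxyazetidin-1-yl shows no change beyond the scatter. The steps to compound 4 from compound 1 and from compound 3 cannot be read, since both ends of each are limits.

From the compounds shown here alone, how far these limited compounds actually lie from compound 2 stays open. A methyl ester in place of the carboxylic acid, or a plain piperidine without it, could show whether the carboxylic acid matters at this place at all.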